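The compounds below may be only part of what the source reports. "The series", "measured", "known", "first", "only" and "open" are said of these compounds alone.

Measured compounds in this assay:
compound 1 `CN1[C@@H]2c3[nH]c4ccccc4c3C[C@H]1[C@H](C#N)N1[C@@H](CNC(=O)c3ccc(Cl)cc3)c3[nH]c4ccccc4c3C[C@@H]21` — 130 nM
compound 2 `CN1[C@@H]2c3[nH]c4ccccc4c3C[C@H]1[C@H](C#N)N1[C@@H](CNC(=O)c3ccc(F)cc3)c3[nH]c4ccccc4c3C[C@@H]21` — 1370 nM
compound 3 `CN1[C@@H]2c3[nH]c4ccccc4c3C[C@H]1[C@H](C#N)N1[C@@H](CNC(=O)c3ccc4ccccc4c3)c3[nH]c4ccccc4c3C[C@@H]21` — 4940 nM

In a functional assay on HT-29 cells (Homo sapiens) for cytotoxicity, read by MTT assay, with a stated time of 72 h (on this read-out lower numbers stand for stronger inhibition and higher numbers for weaker inhibition), compound 3 gives the highest number of the three: a 38-fold higher number from compound 1 to compound 3 (1.58 log units; beyond the scatter) and a 3.6-fold higher number from compound 2 to compound 3 (0.56 log units; beyond the scatter), both beyond the scatter. Compound 4 `CN1[C@@H]2c3[nH]c4ccccc4c3C[C@H]1[C@H](C#N)N1[C@@H](CNC(=O)c3ccc4ccccc4n3)c3[nH]c4ccccc4c3C[C@@H]21` differs from compound 3 by quinolin-2-yl in place of naphthalen-2-yl on a carbonyl carbon. Among the measured compounds shown here, no measured step exchanges an aryl group for a ring-nitrogen analogue. The steps that touch the acyl group, an 11-fold higher number from compound 1 to compound 2 (1.02 log units; beyond the scatter) and a 38-fold higher number from compound 1 to compound 3 (1.58 log units; beyond the scatter), show that changes at this position can move the number a long way, but they give no direction for the present change. Compound 4 is therefore expected to stay near compound 3, with a 1.2-fold lower number from compound 3 to compound 4 (0.09 log units; within the scatter) not beyond the scatter, though a wide range is kept. The estimate for compound 4 is 4000 nM, from 1300 nM to 13000 nM.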

Compound 4, half-maximal inhibitory concentration: 150 nM
Beside the measured number, compound 4's estimate is 27-fold (1.43 log units) above it; measured number below the stated range.
By their numbers in this assay, from the lowest: compounds 1 and 4 (each within the scatter of the next); then compound 2; then compound 3.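

In this assay, the acyl position responds strongly to a single ring atom: a 33-fold lower number from compound 3 to compound 4 (1.52 log units; beyond the scatter), as quinolin-2-yl brings a hydrogen-bond acceptor that naphthalen-2-yl lacks. The larger aryl group is therefore not unfavourable in itself: a 9.1-fold lower number from compound 2 to compound 4 (0.96 log units; beyond the scatter), while a 1.2-fold higher number from compound 1 to compound 4 (0.06 log units; within the scatter) leaves compound 4 and compound 1 unordered. No measurement here bears on why this exchange has such an effect.

Going by these compounds, it remains open whether pyridin-2-yl, which keeps the ring nitrogen on a single ring, would retain the low number. Isoquinolin-3-yl would test where that nitrogen is needed, and a chloro-substituted quinolin-2-yl would test whether the two favourable groups combine.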